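Swapping a Cyclohexyl for a Thiazole on a Shared Core

The source may report more compounds than this note shows. Statements on the series, on what has been measured and on what is new or still open speak of the compounds shown alone.

Measured compounds:
Compound 1, `Cc1ccc(S(=O)(=O)n2c(CCCN3C(=O)c4ccccc4C3=O)nc3cc(Cl)c(Cl)cc32)cc1`: 13000 nM
Compound 2, `Cn1c(CCC2CCCCC2)nc2cc(Cl)c(Cl)cc21`: > 500000 nM

Of the compounds shown here, two have been tested in a functional assay on HepG2 cells (Homo sapiens) for cytotoxicity; a higher number here means that more compound is tolerated, a lower number that less compound is tolerated. Compound 1, whose structure is `Cc1ccc(S(=O)(=O)n2c(CCCN3C(=O)c4ccccc4C3=O)nc3cc(Cl)c(Cl)cc32)cc1`, gives 13000 nM in this assay. Compound 2, whose structure is `Cn1c(CCC2CCCCC2)nc2cc(Cl)c(Cl)cc21`, does not give a number in this assay; its result is a limit, > 500000 nM. That limit is described by the limit of > 500000 nM in this assay, at which 1 of the 2 values shown sits, and it means compound 2 sits at the edge of what this assay can report, so only a lower bound on the tolerated amount is known.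

Compound 3, whose structure is `Cn1c(CCc2nccs2)nc2cc(Cl)c(Cl)cc21`, has not yet been measured. It differs from compound 2 in one place: 1,3-thiazol-2-yl in place of cyclohexyl on a saturated chain carbon, two bonds along the chain from an aromatic carbon. Among the measured compounds shown here, no step between measured compounds links these two, so the expectation for compound 3 rests on compound 2 alone. Since compound 2 shows only a limit, compound 3 is expected to stay near that limit as well, with no change that can be told apart from the scatter; the expected step from compound 2 to compound 3 is an at least 1.2-fold lower number from compound 2 to compound 3 (0.09 log units; that floor lies within the scatter). Compound 3 is therefore estimated at 400000 nM, within a range from 100000 nM to 1000000 nM, with a good chance that this assay again reports only a limit.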

Compound 3, half-maximal cytotoxic concentration: 16000 nM
Compound 3: middle estimate off by 25-fold (1.40 log units), on the high side; the whole stated range lies above it.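

On a saturated chain carbon, two bonds along the chain from an aromatic carbon, the choice of group turns out to matter a great deal in this assay: putting 1,3-thiazol-2-yl in place of cyclohexyl gives an at least 31-fold lower number from compound 2 to compound 3 (1.49 log units; beyond the scatter). Compound 2 alone gave no number, so it could not show that this position had any hold on the read-out; compound 3 shows that the shared core with this chain is not well tolerated whatever group it carries. The true size of the step may be larger than the printed floor, because the result for compound 2 is a limit and not a number: the limit of > 500000 nM in this assay, at which 1 of the 3 values shown sits.

On these data alone, whether the lower number follows from the nitrogen and sulfur of the new ring, or simply from an aromatic ring standing in place of a saturated one, stays open, and a phenyl group on the same chain carbon would separate the two. Also open, as far as these compounds go, is whether the same swap has a step of this size with a longer chain joining the ring to the shared core.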